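Compound 3 to compound 4: an aryl exchange at the limit

The source may report more compounds than this note shows. Statements on the series, on what has been measured and on what is new or still open speak of the compounds shown alone.

Three compounds sharing one core differ only in the aryl group on a nitrogen on an aromatic ring. In a functional assay on U-87MG ATCC cells for antiproliferative activity against U-87 MG (Homo sapiens), read by spectrophotometry, with a stated time of 2 days (on this read-out lower numbers stand for stronger inhibition of growth and higher numbers for weaker inhibition of growth), compound 1 `Cc1ccc(Nc2ncc(C(F)(F)F)c(N3Cc4cccc(N(C)S(C)(=O)=O)c4C3)n2)c(Cl)c1` gives > 30000 nM as a limit of the assay. In this assay compound 2 `Cc1cc(C)cc(Nc2ncc(C(F)(F)F)c(N3Cc4cccc(N(C)S(C)(=O)=O)c4C3)n2)c1` gives > 30000 nM as a limit too. Compound 3 `COc1cc(Nc2ncc(C(F)(F)F)c(N3Cc4cccc(N(C)S(C)(=O)=O)c4C3)n2)cc(C(F)(F)F)c1` gives > 30000 nM in this assay and this is also a limit, so compound 3 offers no number as a starting point.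

The next member is compound 4 `CN(c1cccc2c1CN(c1nc(Nc3ccc(Cl)c(C(F)(F)F)c3)ncc1C(F)(F)F)C2)S(C)(=O)=O` and the difference 4-chloro-3-(trifluoromethyl)phenyl in place of 3-methoxy-5-(trifluoromethyl)phenyl on a nitrogen on an aromatic ring puts 4-chloro-3-(trifluoromethyl)phenyl in place of 3-methoxy-5-(trifluoromethyl)phenyl on a nitrogen on an aromatic ring. Three measured exchanges at this same place bear on it: a step that the two limits leave unreadable from compound 1 to compound 2 and a step that the two limits leave unreadable from compound 1 to compound 3 and a step that the two limits leave unreadable from compound 2 to compound 3 supply no size to carry over. Compound 3 and its two neighbours leave the limit of > 30000 nM in this assay, at which 3 of the 3 values shown sit, as the whole record, so no step beyond the scatter is expected in this assay in either direction. The expected step is a number no higher from compound 3 to compound 4 (the limit leaves the size open) and a further limit is the likeliest report. Compound 4 is estimated at 30000 nM with 10000 nM to 50000 nM as the expected range.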

Compound 4, concentration for 50% growth inhibition: > 30000 nM
Compound 4: no number, only a limit (the forecaster's own chance of this, stated with the estimate: 75%); the middle value sits exactly at the limit.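

In this assay compound 4 gives > 30000 nM, which is a limit of the assay and not a number. No new step can be read: the exchanges linking compound 4 with compound 1, compound 2 and compound 3 each join two limits. The compounds shown leave open how these aryl groups rank and whether any gives a measurable value on the shared core, with the record standing at the limit of > 30000 nM in this assay, at which 4 of the 4 values shown sit.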